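Taking the Benzyloxycarbonyl Group off Compound 2

This account rests on a few compounds, and the source may have more. Where it says the series, first, only, none or still open, it means among the compounds named here.

Among the compounds with values here, only two compounds have been measured so far in a functional assay on A549 cells (Homo sapiens) for antiproliferative activity, read by sulforhodamine B assay, with a stated time of 72 h; on this read-out lower numbers stand for stronger inhibition and higher numbers for weaker inhibition. There, compound 1 `COc1cc(/C=C2\CCC=CC2=O)cc2ccccc12` gives 1630 nM, while compound 2 `COc1cc(/C=C2\CN(C(=O)OCc3ccccc3)C=CC2=O)cc(OC)c1OC` gives 21300 nM. Compound 2 therefore holds the higher of the two numbers, and the gap between them lies beyond the usual scatter. Compound 3 `COc1cc(/C=C2\CNC=CC2=O)cc(OC)c1OC` differs from compound 2 by a single change, hydrogen in place of benzyloxycarbonyl on an amine nitrogen in a ring. Within the data shown here, no measured pair shows a change of this kind, so the expectation rests on little and stays cautious. In this assay, the expected move is small, a 1.4-fold higher number from compound 2 to compound 3 (0.15 log units; within the scatter), leaning towards weaker inhibition and probably not beyond the scatter. For compound 3 the estimated value is 30000 nM, with an expected range of 8000 nM to 100000 nM.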

Compound 3, half-maximal inhibitory concentration: > 25000 nM
Compound 3: a limit, no number (the forecaster's own chance of this, stated with the estimate: 25%); the middle value lies beyond the limit too.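

Within the data shown here, no earlier pair had tested this position, the amine nitrogen in the ring, and in this assay replacing benzyloxycarbonyl with hydrogen gives an at least 1.1-fold higher number from compound 2 to compound 3 (0.06 log units; that floor lies within the scatter). The reading for compound 3 is a limit of the assay and not a number: the limit of > 25000 nM in this assay, at which 1 of the 3 values shown sits. The change therefore brought no stronger inhibition, and only a floor is known for the step, so it remains unclear whether inhibition is actually weaker than with compound 2.

The compounds shown leave open whether a small group on this ring nitrogen, such as a methyl or an acetyl, would give a number clearly apart from that of compound 2. Compound 1 differs from compound 3 in more than one place, so nothing here ties its value to the ring nitrogen alone.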